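Compound 3 against two measured neighbours

The source may report more compounds than this note shows. Statements on the series, on what has been measured and on what is new or still open speak of the compounds shown alone.

Measured in a functional assay on MDA-MB-231 cells (Homo sapiens) for cytotoxicity, read by MTT assay, with a stated time of 96 h (on this read-out higher numbers stand for weaker inhibition and lower numbers for stronger inhibition), so far
compound 1 `N=C(N)c1ccc(-c2ccc(-c3cccc([N+](=O)[O-])c3)o2)cc1` gives 2900 nM
compound 2 `Cc1ccc(-c2ccc(-c3ccc(C(=N)N)cc3)o2)cc1` gives 3400 nM

Compound 2 stands within the scatter of compound 1, so the two values set no order. Compound 3 `N=C(N)c1ccc(-c2ccc(-c3cccc(F)c3)o2)cc1` differs from compound 2 by 3-fluorophenyl in place of 4-methylphenyl on an aromatic carbon with 3-fluorophenyl in place of 4-methylphenyl on an aromatic carbon next to the ring oxygen. Within the data shown here, no step between measured compounds is available. With compound 2 at 3400 nM as the reference, no change beyond the scatter is expected in this assay for this swap. The expected 1.1-fold lower number from compound 2 to compound 3 (0.05 log units; within the scatter) stays within the scatter. Compound 3 is estimated at 3000 nM within a range from 1200 nM to 7000 nM.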

Compound 3, half-maximal inhibitory concentration: 2000 nM
Compound 3: middle estimate off by 1.5-fold (0.18 log units), on the high side, within the range that was stated.
By their numbers in this assay, from the lowest: compounds 3, 1 and 2 (each within the scatter of the next).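

At the aromatic carbon next to the ring oxygen, 3-fluorophenyl in place of 4-methylphenyl gives a 1.7-fold lower number from compound 2 to compound 3 (0.23 log units; within the scatter) in this assay. On the same aryl group, fluoro in place of nitro gives a 1.5-fold lower number from compound 1 to compound 3 (0.16 log units; within the scatter). Methyl, nitro and fluoro on these aryl groups therefore set no order among compounds 1, 2 and 3, and no swap shown here yet moves the number beyond the scatter.

Still open, as far as these compounds go, is whether an amine or a carboxylic acid on this aryl group, or a longer chain in its place, would do so. Nothing at hand bears on the reason for these small steps.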